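This account rests on a few compounds, and the source may have more. Where it says the series, first, only, none or still open, it means among the compounds named here.

In a functional assay, with a stated time of 20 min, tested at 0.1 mM (on this read-out lower numbers stand for a weaker effect and higher numbers for a stronger effect at the one concentration tested), compound 2 `Cn1c(=O)c(C(=O)NCCCCCCN)c(O)c2ccccc21` gives 3.1%, the lowest of the three numbers seen, though both gaps stay within the scatter: compound 1 `Cn1c(=O)c(C(=O)NCCN)c(O)c2ccccc21` gives 5.6%, with a number 2.5 percentage points lower from compound 1 to compound 2 (within the scatter), and compound 3 `NCCCCCCNC(=O)c1c(O)c2ccccc2n(-c2ccccc2)c1=O` gives 11.6%, with a number 8.5 percentage points higher from compound 2 to compound 3 (within the scatter). Compound 4 `Cn1c(=O)c(C(=O)Nc2ccccc2N)c(O)c2ccccc21` differs from compound 2 by 2-aminophenyl in place of 6-aminohexyl on an amide-type nitrogen. The step from compound 1 to compound 2 also swapped the group on that amide-type nitrogen and stayed within the scatter; the step from compound 2 to compound 3 touched another place. Going by the values given here, no measured step shows an aromatic ring replacing a chain here, so nothing beyond the scatter is expected. Compound 4 is therefore estimated at 6%, between 0% and 18%, an expected a number 2.9 percentage points higher from compound 2 to compound 4 (within the scatter).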

Compound 4, a percentage reported as activity, at one concentration (the size of the read-out at that concentration, not a potency): 6%
The estimate for compound 4 equals the measured number at the digits printed; low and high end bracket the measured number.
By their numbers in this assay, from the lowest: compounds 2, 1, 4 and 3 (each within the scatter of the next).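

In this assay, putting an aromatic ring on the amide-type nitrogen gives a number that cannot be told apart from those of the saturated chains: a number 2.9 percentage points higher from compound 2 to compound 4 (within the scatter), and a number 0.4 percentage points higher from compound 1 to compound 4 (within the scatter). At this place, 2-aminophenyl, 6-aminohexyl and 2-aminoethyl all stay within the scatter of one another, so neither the ring nor the chain length separates them. Nothing measured here speaks to why the numbers sit so close. Still open, on these data alone, is whether any group on this nitrogen can move the number beyond the scatter. Benzyl, or a longer chain ending in a carboxylic acid, would test this.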